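The source may report more compounds than this note shows. Statements on the series, on what has been measured and on what is new or still open speak of the compounds shown alone.

Measured in an assay on isolated protein for binding affinity to corticotropin-releasing factor receptor 1 (Homo sapiens); on this read-out lower numbers stand for stronger inhibition and higher numbers for weaker inhibition:
compound 1 `CCCN(CCC)c1cc(C)nc2c(-c3ncc(C(F)(F)F)cc3Cl)c(C)nn12` gives 1.2 nM;
compound 2 `CCCN(CCC)c1cc(C)nc2c(-c3ccc(Cl)cn3)c(C)nn12` gives 88 nM;
compound 3 `CCCN(CCC)c1cc(C)nc2c(-c3ncc(N)cc3C)c(C)nn12` gives 85 nM.

All three share one core and differ only in the aromatic ring attached to it. Compound 3 stands second highest of the three numbers. The step of a 1.0-fold lower number from compound 2 to compound 3 (0.02 log units; within the scatter) lies within the scatter, so these two cannot be told apart, while compound 1 sits far lower, beyond the scatter. Compound 4 `CCCN(CCC)c1cc(C)nc2c(-c3ncc(N(CC)CC)cc3C)c(C)nn12` has not yet been measured. It differs from compound 3 in one place: diethylamino in place of amino on an aromatic carbon. Among the compounds with values here, no measured step covers this exchange. Within the data shown here, the one single-place step that was measured swapped the whole ring substitution and stayed within the scatter, and compound 1 shows that a different substitution of this ring can shift the number a long way, but neither shows how a larger amino group behaves. The expected step is therefore uncertain; compound 4 is estimated to come out as a 2.1-fold lower number from compound 3 to compound 4 (0.33 log units; beyond the scatter), at 40 nM with a range from 8 nM to 200 nM in this assay.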

Compound 4, inhibition constant: 13 nM
The estimate for compound 4 lay 3.1-fold (0.49 log units) above the measured number, within the range that was stated.
By their numbers in this assay, from the lowest: compound 1; then compound 4; then compounds 3 and 2 (each within the scatter of the next).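

At this position, two atoms from the ring nitrogen, a larger group is accepted and the number improves: in this assay, diethylamino in place of amino gives a 6.5-fold lower number from compound 3 to compound 4 (0.82 log units; beyond the scatter). This step changes one group on the aromatic ring, so it shows that the number goes down as amino, with its hydrogen-bond donor, gives way to the larger diethylamino, which has none. No measurement here explains why the number falls.

The compounds shown leave open whether the larger size or the lost donor matters more, and ethylamino, which keeps a hydrogen on its nitrogen, would help to separate the two. Going by these compounds, it also remains open how far the chains can grow, as with dipropylamino, or whether a ring amine such as pyrrolidine would serve as well.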